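Chloro-to-methyl swap and solubility across two cores

The source may hold more compounds than are shown below. What is called first, only, known or untested is meant among the compounds shown, and "the series" means these compounds.

Compound 1, `CCNCc1cc(C)cc(Nc2nc3ccccc3n2Cc2ccc(C(F)(F)F)cc2)c1O` — in a physicochemical assay for solubility, read by HPLC, measured as kinetic solubility, with a stated time of 24 h, at pH 6.5 (on this read-out higher numbers stand for higher solubility and lower numbers for lower solubility), compound 1 gives 35000 nM.
Compound 2, `CCNCc1cc(Cl)cc(Nc2nc3ccccc3n2Cc2ccc(C(F)(F)F)cc2)c1O` — in this assay compound 2 gives 12000 nM.
Compound 3, `CCNCc1cc(Cl)cc(Nc2nc3cc(F)c(F)cc3n2Cc2ccc(C(F)(F)F)cc2)c1O` — in this assay compound 3 gives < 5000 nM, which is a limit of the assay and not a number; this is the limit of < 5000 nM in this assay, at which 1 of the 3 values shown sits.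

Among the compounds with values here, the one measured change, (methyl in place of chloro on an aromatic carbon), produces a 2.9-fold higher number from compound 2 to compound 1 (0.46 log units; beyond the scatter). How the core of compound 3 differs from the core of compound 2 is not broken down here. Compound 4, `CCNCc1cc(C)cc(Nc2nc3cc(F)c(F)cc3n2Cc2ccc(C(F)(F)F)cc2)c1O`, carries the same change applied to the core of compound 3: methyl in place of chloro on an aromatic carbon. Within the data shown here, for compound 4 the expected step in this assay is an at least 2.0-fold higher number from compound 3 to compound 4 (0.30 log units; that floor lies within the scatter), taken to be comparable in size to a 2.9-fold higher number from compound 2 to compound 1 (0.46 log units; beyond the scatter), which is the single measured instance of this change, while compound 3 supplies only a limit as the starting point. Compound 4 is thus estimated at 10000 nM, with a range from 4000 nM to 25000 nM.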

Compound 4, solubility: 16000 nM
The estimate for compound 4 lay 1.6-fold (0.20 log units) below the measured number; low and high end bracket the measured number.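

In this assay, methyl in place of chloro gives an at least 3.2-fold higher number from compound 3 to compound 4 (0.50 log units; beyond the scatter), and the same change on the other core gives a 2.9-fold higher number from compound 2 to compound 1 (0.46 log units; beyond the scatter): both steps point the same way, so the direction carries across these two cores. Compound 3 stands only at a limit of the assay, not a number: the limit of < 5000 nM in this assay, at which 1 of the 4 values shown sits. The step on its core is a floor, and these two pairs do not show whether the change has the same size on both cores or would hold on any other core.

Open, on these data alone, is how a methoxy group, a nitrile or a longer chain such as ethyl would read on that aromatic carbon in this assay. Also open, as far as these compounds go, is how a carboxylic acid in place of the (ethylamino)methyl group would read on either core.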